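The source may report more compounds than this note shows. Statements on the series, on what has been measured and on what is new or still open speak of the compounds shown alone.

Three measured compounds frame this step. In a physicochemical assay for solubility, in phosphate buffer, measured as thermodynamic solubility, at pH 7.4 (a higher number here means a more soluble compound, a lower number a less soluble compound), compound 1 (`CS(=O)(=O)NC(=O)CCc1cn(-c2ccccc2)nc1-c1ccc(Cl)cc1`) gives 200000 nM and compound 2 (`CS(=O)(=O)NC(=O)CCc1cn(-c2ccc(Br)cc2)nc1-c1cccnc1`) gives 200000 nM as its reading. Compound 3 (`CS(=O)(=O)NCCCc1cn(-c2ccc(Br)cc2)nc1-c1ccc(Cl)cc1`) returns < 5000 nM as its reading, which is a limit and not a number. Compound 3 thus stands at the limit of < 5000 nM in this assay, at which 1 of the 3 values shown sits, and offers no exact starting point.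

Compound 4 (`O=C(CCc1cn(-c2ccc(Br)cc2)nc1-c1ccc(Cl)cc1)NS(=O)(=O)C1CC1`) keeps the core of compound 3 and changes the chain: (cyclopropylsulfonyl)carbamoyl comes in place of (methanesulfonamido)methyl on a saturated chain carbon, two bonds along the chain from an aromatic carbon ((cyclopropylsulfonyl)carbamoyl in place of (methanesulfonamido)methyl on a saturated chain carbon, two bonds along the chain from an aromatic carbon). Among the measured compounds shown here, no measured pair isolates this change, so the expectation rests on thin ground. Compound 1 with its 200000 nM reading and compound 2 with its 200000 nM reading carry a carbamoyl chain as compound 4 does, whereas compound 3 does not. A clear upward step in this assay is therefore expected, estimated as an at least 16-fold higher number from compound 3 to compound 4 (1.20 log units; beyond the scatter) and beyond the scatter. Compound 4 is estimated at 80000 nM with 15000 nM to 200000 nM as the expected range.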

Compound 4, solubility: 5000 nM
For compound 4 the middle estimate is 16-fold (1.20 log units) above the measured one; the whole stated range lies above it.
By their numbers in this assay, from the lowest: compound 4; then compounds 1 and 2 (each within the scatter of the next).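

In this assay, putting (cyclopropylsulfonyl)carbamoyl in place of (methanesulfonamido)methyl on a saturated chain carbon, two bonds along the chain from an aromatic carbon, gives a number no lower from compound 3 to compound 4 (the limit leaves the size open). Compound 3 holds only a limit and not a number, and the size of this step cannot be read for that reason: the limit of < 5000 nM in this assay, at which 1 of the 4 values shown sits.
Among the compounds shown here, compounds 1 and 2 each differ from compound 4 in more than one place, so neither isolates the chain, and compound 4 with 5000 nM is the only exact reading for the change itself.

The compounds shown leave open how much of the change belongs to the cyclopropyl ring and how much to the carbamoyl group. They also leave open how a carboxylic acid or a primary amine at this place would read in this assay.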